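The source may report more compounds than this note shows. Statements on the series, on what has been measured and on what is new or still open speak of the compounds shown alone.

Of the compounds shown here, three measured so far carry the same core and differ only in the five-membered ring attached to it. In a functional assay on HCT-116 cells (Homo sapiens), read by sulforhodamine B assay, with a stated time of 5 days (a lower number here means a stronger inhibitor of growth, a higher number a weaker inhibitor of growth), compound 3 `OC[C@H]1O[C@@H](n2cc(F)c3c(-c4ccsc4)ncnc32)[C@H](O)[C@@H]1O` gives 140 nM, the lowest number of the series. Compound 1 `OC[C@H]1O[C@@H](n2cc(F)c3c(-c4ccc[nH]4)ncnc32)[C@H](O)[C@@H]1O` gives 450 nM. Compound 2 `OC[C@H]1O[C@@H](n2cc(F)c3c(-c4c[nH]cn4)ncnc32)[C@H](O)[C@@H]1O` reads > 10000 nM, which is a limit of the assay and not a number.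

Compound 4 `OC[C@H]1O[C@@H](n2cc(F)c3c(-c4cc[nH]c4)ncnc32)[C@H](O)[C@@H]1O` is still unmeasured. It has 1H-pyrrol-3-yl in place of thiophen-3-yl on an aromatic carbon.

The closest guide is the modest 3.2-fold lower number from compound 1 to compound 3 (0.51 log units; beyond the scatter), which also exchanges a pyrrole ring for thiophen-3-yl, although there the ring is 1H-pyrrol-2-yl. The large at least 22-fold higher number from compound 1 to compound 2 (1.34 log units; beyond the scatter) and an at least 71-fold lower number from compound 2 to compound 3 (1.85 log units; beyond the scatter) show that a ring exchange can matter greatly, but both involve 1H-imidazol-4-yl, which compound 4 does not carry.

A modest move to a higher number in this assay is therefore expected, with the estimated step being a 2.1-fold higher number from compound 3 to compound 4 (0.33 log units; beyond the scatter). The estimate for compound 4 is 300 nM, with an expected range of 70 nM to 1200 nM.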

Compound 4, concentration for 50% growth inhibition: 250 nM
Compound 4: the middle estimate sits 1.2-fold (0.08 log units) above what was measured, and the stated range covers the measured number.
By their numbers in this assay, from the lowest: compounds 3, 4 and 1 (each within the scatter of the next, the first and the last beyond it). At a limit, above all of these: compound 2.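

In this assay, replacing thiophen-3-yl with 1H-pyrrol-3-yl gives a 1.8-fold higher number from compound 3 to compound 4 (0.25 log units; within the scatter), and moving the attachment point of the pyrrole gives a 1.8-fold lower number from compound 1 to compound 4 (0.26 log units; within the scatter), so neither the added hydrogen-bond donor nor the switch from 1H-pyrrol-2-yl to 1H-pyrrol-3-yl produces a change that can be told from scatter. A ring with a hydrogen-bond donor is therefore compatible with growth inhibition at this position, and the 1H-imidazol-4-yl ring of compound 2 stands apart, with an at least 40-fold lower number from compound 2 to compound 4 (1.60 log units; beyond the scatter). Compound 2 sits at a limit of the assay, so that step has no exact size: the limit of > 10000 nM in this assay, at which 1 of the 4 values shown sits.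

The compounds shown do not reveal which feature of 1H-imidazol-4-yl separates it from the two pyrroles. Also open, from the compounds shown here alone, is how a six-membered pyridine ring, or an amine or carboxylic acid on the five-membered ring, would read here.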